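Notes on a diaryl amide series against the dehydrogenase

The compounds below may be only part of what the source reports. "The series", "measured", "known", "first", "only" and "open" are said of these compounds alone.

Of the compounds shown here, three have been measured in an assay for inhibition of 17-beta-hydroxysteroid dehydrogenase type 1 (Homo sapiens), read by HPLC, with a stated time of 10 min; on this read-out higher numbers stand for weaker inhibition and lower numbers for stronger inhibition. Compound 1 `COc1cccc(N(C)C(=O)C2CCC(c3ccc(Cl)cc3)CC2)c1` gives 60100 nM in this assay. Compound 3 `COc1cccc(N(C)C(=O)c2ccc(-c3ccc(C)c(C)c3)cc2)c1` gives 13300 nM in this assay. Compound 2 `Cc1cccc(N(C)C(=O)c2ccc(Oc3ccccc3)cc2)c1` is recorded as "not active" (no number reported) in this assay, so no number is available for it, and it therefore cannot be placed against compound 1 or compound 3 on the scale.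

Compound 4 `Cc1cccc(Oc2ccc(C(=O)N(C)c3cccc(C)c3)cc2)c1` is not yet measured. It differs from compound 2 by methyl in place of hydrogen on an aromatic carbon, a methyl in place of hydrogen on an aromatic carbon. Within the data shown here, no measured pair shows the size of such a step, so it is taken as small in this assay, in no fixed direction, and compound 2 offers no number to start from. Compound 4 is expected to give about 50000 nM, within 12000 nM to 200000 nM, with a fair chance of again being recorded without a number.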

Compound 4, half-maximal inhibitory concentration: 16100 nM
Compound 4: the middle estimate sits 3.1-fold (0.49 log units) above what was measured; the range from low to high includes it.
By their numbers in this assay, from the lowest: compounds 3 and 4 (each within the scatter of the next); then compound 1.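

Among these compounds, compound 2 carries no number in this assay, so no step from it to compound 4 can be read. No supporting data bear on a cause for this result. The compounds shown leave open how large the change from phenoxy to 3-methylphenoxy is.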